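This account rests on a few compounds, and the source may have more. Where it says the series, first, only, none or still open, it means among the compounds named here.

Measured so far:
compound 1 `O=C(CN1C(=O)S/C(=C/c2ccco2)C1=O)Nc1ccc(Cl)c(Cl)c1` gives 7800 nM
compound 2 `O=C(CN1C(=O)S/C(=C/c2ccco2)C1=O)Nc1nc2ccccc2s1` gives 1700 nM

Both numbers come from a functional assay on CCRF-CEM cells (Homo sapiens) for cytotoxicity, read by propidium iodide staining, with a stated time of 48 h (on this read-out lower numbers stand for higher toxicity in this test and higher numbers for lower toxicity in this test), and differ by more than the usual scatter. Compound 1 stands higher of the two, so it is the less toxic compound in this pair. Compound 3 `Cc1cc(NC(=O)CN2C(=O)S/C(=C/c3ccco3)C2=O)no1` is still unmeasured. Its change from compound 1 is 5-methyl-1,2-oxazol-3-yl in place of 3,4-dichlorophenyl on an amide-type nitrogen and nothing else. Going by the values given here, no step between measured compounds is available to size this change, so the expectation is loose. In this assay no step beyond the scatter is expected, with a slight lean towards a higher number. The estimated value for compound 3 is 10000 nM with an expected range from 3000 nM to 30000 nM as the working bounds. This estimate means an expected 1.3-fold higher number from compound 1 to compound 3 (0.11 log units; within the scatter) in the notes on this series.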

Compound 3, half-maximal cytotoxic concentration: > 100000 nM
Compound 3: only a limit was reported (the forecaster's own chance of this, stated with the estimate: 10%); middle value at least 10-fold (1.00 log units) away from the limit.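

In this assay, the group on the amide-type nitrogen proves able to decide the read-out on its own: 5-methyl-1,2-oxazol-3-yl in place of 3,4-dichlorophenyl gives an at least 12-fold higher number from compound 1 to compound 3 (1.10 log units; beyond the scatter). The reading for compound 3 is a limit of the assay, not a number: the limit of > 100000 nM in this assay, at which 1 of the 3 values shown sits. The earlier compounds shown here gave two values but no sized step at this position, whereas this single change, with the rest of compound 1 kept, shifts the result well beyond the scatter towards lower toxicity in this test.

The limit leaves the full size of the step unknown, and this one exchange does not separate the loss of the chlorine atoms from the change of ring. On these data alone, whether a plain phenyl on the same nitrogen would read like compound 1 or like compound 3 stays open.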